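Aryl amide variation from compound 1 to compound 4

A few compounds are considered here, and "the series" means these few. Any claim that something is new, unique, unknown or untested is made for them only; others in the source may bear on it.

Compound 1 `Cc1cc(C(=O)NCN2CCC(c3cccc[n+]3[O-])CC2)ccc1F` gives 50 nM in a functional assay on HEK293 cells for agonist activity at D(4) dopamine receptor (Homo sapiens), read by FLIPR (a higher number here means that more compound is needed for the effect, a lower number that less compound is needed), the second highest of the three numbers in hand. Compound 2 `Cc1cccc(C(=O)NCN2CCC(c3nccs3)CC2)c1` gives 9.8 nM, a lower number beyond the scatter, and compound 3 `COc1ccccc1C1CCN(CC(=O)Nc2cccc(C)c2)CC1` gives 420 nM, a higher number beyond the scatter; neither pair shares a single-point change with compound 1, so only the values themselves stand side by side. Compound 4 `C=Cc1cccc(C(=O)NCN2CCC(c3cccc[n+]3[O-])CC2)c1` is not yet measured. It differs from compound 1 by 3-vinylphenyl in place of 4-fluoro-3-methylphenyl on a carbonyl carbon, keeping the amide and the shared core of compound 1. For the measured compounds named here, no measured step covers this change; a small movement toward a lower number, close to the scatter, is expected, a 1.7-fold lower number from compound 1 to compound 4 (0.22 log units; within the scatter). Compound 4 is estimated at 30 nM, with a range from 8 nM to 120 nM.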

Compound 4, half-maximal effective concentration: 68 nM
Beside the measured number, compound 4's estimate is 2.3-fold (0.36 log units) below it, within the range that was stated.
By their numbers in this assay, from the lowest: compound 2; then compounds 1 and 4 (each within the scatter of the next); then compound 3.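

In this assay, for the compounds shown here, the first single-place step is a 1.4-fold higher number from compound 1 to compound 4 (0.13 log units; within the scatter), with 3-vinylphenyl in place of 4-fluoro-3-methylphenyl on a carbonyl carbon. At this place, then, losing the fluorine and bringing in a double bond outside aromatic rings gives no change that can be told from the scatter. No measurement in hand bears on the reason for this result. From the compounds shown here alone, whether an amine, a carboxylic acid or a longer chain on this aryl ring would move the number stays open. Steps linking compound 2 or compound 3 to the others cannot be read.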